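Nitro to amino on a phenyl-chromone pair

The source may report more compounds than this note shows. Statements on the series, on what has been measured and on what is new or still open speak of the compounds shown alone.

Compound 1 `COC(=O)c1c(-c2ccc([N+](=O)[O-])cc2)oc2ccccc2c1=O` and compound 2 `COC(=O)c1c(-c2ccc(N)cc2)oc2ccccc2c1=O` share a core that carries a methyl ester; compound 3 `O=c1cc(-c2ccc([N+](=O)[O-])cc2)oc2ccc(O)cc12` and compound 4 `Nc1ccc(-c2cc(=O)c3cc(O)ccc3o2)cc1` share a core that carries a hydroxyl instead. How the two cores differ is not broken down here. In a functional assay on A549 cells (Homo sapiens) for cytotoxicity, read by MTT assay, with a stated time of 6 days (a higher number here means that more compound is needed for the effect, a lower number that less compound is needed), compound 1 gives only a limit, > 25 ug/mL. In this assay compound 2 likewise gives only a limit, > 25 ug/mL. In this assay compound 3 gives 5.07 ug/mL. The change from compound 1 to compound 2 is amino in place of nitro on an aromatic carbon, and the measured step is a step that the two limits leave unreadable from compound 1 to compound 2, because both values sit at the limit of > 25 ug/mL in this assay, at which 2 of the 3 values shown sit. The change from compound 3 to compound 4 is amino in place of nitro on an aromatic carbon, the same change on the other core. The earlier step therefore tells nothing about its size. For compound 4 a step of a 1.6-fold higher number from compound 3 to compound 4 (0.20 log units; within the scatter) is expected, resting only on the value of compound 3, 5.07 ug/mL, since the pair of compound 1 and compound 2 gives no readable size. Compound 4 is estimated at 8 ug/mL, within a range of 2.5 ug/mL to 25 ug/mL.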

Compound 4, concentration for half-maximal effect: 2.72 ug/mL
Compound 4: the middle estimate sits 2.9-fold (0.47 log units) above what was measured, and the stated range covers the measured number.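

In this assay, amino in place of nitro on the core carrying the hydroxyl gives a 1.9-fold lower number from compound 3 to compound 4 (0.27 log units; within the scatter), so on this core compound 3 and compound 4 cannot be told apart. On the core carrying the methyl ester the same change cannot be read, because compound 1 and compound 2 each give only a limit: the limit of > 25 ug/mL in this assay, at which 2 of the 4 values shown sit. The series therefore holds a single readable size for this change, which shows neither that the size carries over from one core to the other nor that it differs between them.

As far as these compounds go, how a nitrile or a carboxylic acid on the same aromatic carbon would read in this assay remains open. Also open, from the compounds shown here alone, is whether the step from nitro to amino would stay within the scatter on a core carrying both the hydroxyl and the methyl ester.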